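The compounds below may be only part of what the source reports. "The series", "measured", "known", "first", "only" and "open" are said of these compounds alone.

In an in vitro ADME assay on microsomes (Homo sapiens) for metabolic stability (on this read-out higher numbers stand for fast clearance and lower numbers for slow clearance), compound 2 `O=C(CN(C(=O)c1ccc(-c2ccccn2)cc1)C1CCCCC1)Nc1cc(F)cc(F)c1` gives 5.2 mL.min-1.g-1, level with compound 1 `O=C(CN(C(=O)c1ccc(-n2ccnc2)cc1)C1CCCCC1)Nc1cc(F)cc(F)c1` at 6.1 mL.min-1.g-1, a gap seen as a 1.2-fold lower number from compound 1 to compound 2 (0.07 log units; within the scatter). Compound 3 `O=C(CN(CC1CC1)C(=O)c1ccc(-c2ccccn2)cc1)Nc1cc(F)cc(F)c1` reads < 0.5 mL.min-1.g-1, which is a limit of the assay and not a number. Compound 4 `O=C(CN(C(=O)c1ccc(-c2ccccn2)cc1)C1CCCOC1)Nc1cc(F)cc(F)c1` has oxan-3-yl in place of cyclohexyl on an amide-type nitrogen. The measured step at this same nitrogen is an at least 10-fold lower number from compound 2 to compound 3 (1.01 log units; beyond the scatter), a large one, and it bears most directly on the change. For the measured compounds named here, since a six-membered ring stays and only one ring atom differs, a much smaller move in the same direction is expected in this assay. The expected step is a 2.1-fold lower number from compound 2 to compound 4 (0.32 log units; beyond the scatter). For compound 4 the estimated value is 2.5 mL.min-1.g-1, with an expected range from 1 mL.min-1.g-1 to 5.5 mL.min-1.g-1.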

Compound 4, intrinsic clearance in microsomes: 2.9 mL.min-1.g-1
Beside the measured number, compound 4's estimate is 1.2-fold (0.06 log units) below it, and the stated range covers the measured number.
By their numbers in this assay, from the lowest: compounds 4, 2 and 1 (each within the scatter of the next, the first and the last beyond it). At a limit, below all of these: compound 3.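

In this assay exchanging cyclohexyl for oxan-3-yl on the amide-type nitrogen gives a 1.8-fold lower number from compound 2 to compound 4 (0.25 log units; within the scatter) and so a single ring oxygen does not clearly shift clearance here. Oxan-3-yl and cyclopropylmethyl do part at this nitrogen, with an at least 5.8-fold higher number from compound 3 to compound 4 (0.76 log units; beyond the scatter) and so the very low reading stays with cyclopropylmethyl alone among these groups. Compound 3 stands at a limit and not at a number: the limit of < 0.5 mL.min-1.g-1 in this assay, at which 1 of the 4 values shown sits.

Going by these compounds, how an amine such as piperidin-4-yl, the isomeric oxan-4-yl or a longer chain such as n-butyl would read on this nitrogen stays open.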